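The source may report more compounds than this note shows. Statements on the series, on what has been measured and on what is new or still open speak of the compounds shown alone.

Two compounds have been measured in a functional assay on CHO.K1 cells for antagonist activity at prostaglandin D2 receptor 2 (Homo sapiens), read by GTPgammaS binding, with a stated time of 1 h; a lower number here means a stronger inhibitor, a higher number a weaker inhibitor:

Compound 1, `CNC(=O)c1ccc(Cc2c3c(n(CC(=O)O)c2C)CCNC3=O)c(S(=O)(=O)c2ccccc2)c1`: 10 nM
Compound 2, `Cc1c(Cc2ccccc2S(=O)(=O)c2ccccc2F)c2c(n1CC(=O)O)CCNC2=O`: 3.6 nM

Of these two, compound 2 gives the lower number, and the gap between it and compound 1 lies beyond the usual scatter of the measurement, so compound 2 is the stronger inhibitor of the pair. Compound 3, `Cc1c(Cc2ccccc2S(=O)(=O)C2CCCCC2)c2c(n1CC(=O)O)CCNC2=O`, has not been measured yet. It shares the core of compound 2 and differs from it in one place: cyclohexyl in place of 2-fluorophenyl on a sulfonyl sulfur. For the measured compounds named here, no measured pair in this small set shows what such a change does to the number, so the expectation rests on compound 2 alone. A small loss of strength is expected, of a size that may still fall within the scatter, so the step from compound 2 to compound 3 is estimated at a 2.2-fold higher number from compound 2 to compound 3 (0.35 log units; beyond the scatter). For compound 3 the expected value is 8 nM, with a range from 2 nM to 30 nM.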

Compound 3, half-maximal inhibitory concentration: 28 nM
Beside the measured number, compound 3's estimate is 3.5-fold (0.54 log units) below it, within the range that was stated.
By their numbers in this assay, from the lowest: compound 2; then compound 1; then compound 3.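

In this assay, putting cyclohexyl in place of 2-fluorophenyl on the sulfonyl sulfur gives a 7.8-fold higher number from compound 2 to compound 3 (0.89 log units; beyond the scatter) and so shows that this position responds to the group it carries, with a loss of strength beyond the usual scatter. An aromatic ring is still not strictly needed here for inhibition, since compound 3, with its non-aromatic ring of carbon only, gives 28 nM as its measured value. No measurement available here bears on what lies behind this step.

This single pair changes two things at once, removing both the aromatic ring and the fluorine, so their separate contributions cannot be told apart. Going by these compounds, it also remains open how an unsubstituted phenyl, a smaller cyclopropyl or an open chain such as n-butyl would fare on the same sulfur.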